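This account rests on a few compounds, and the source may have more. Where it says the series, first, only, none or still open, it means among the compounds named here.

Measured compounds:
- compound 1, `N#CCC(=O)NCCSc1nonc1/C(=N/O)Nc1ccc(F)c(C(F)F)c1`, gives 180 nM in an assay for inhibition of Indoleamine 2,3-dioxygenase 1 (Homo sapiens), read by fluorescence, with a stated time of 1 h; on this read-out lower numbers stand for stronger inhibition and higher numbers for weaker inhibition
- compound 2, `CC(C)(O)CC(=O)NCCSc1nonc1/C(=N/O)Nc1ccc(F)c(C(F)F)c1`, gives 140 nM in this assay

Among the measured compounds shown here, of the two numbers measured so far in this assay, compound 2 has the lower one, but its distance to compound 1 is small: a 1.3-fold lower number from compound 1 to compound 2 (0.11 log units; within the scatter), which stays within the scatter of repeated measurements. So nothing separates compound 2 from compound 1 in a meaningful way on this read-out.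

Compound 3, `CS(=O)(=O)CC(=O)NCCSc1nonc1/C(=N/O)Nc1ccc(F)c(C(F)F)c1`, is the next variation on the shared core. The change from compound 2 is methylsulfonyl in place of 1-hydroxy-1-methylethyl on a saturated chain carbon bound to a carbonyl carbon. For the measured compounds named here, only one measured step bears on this position: the exchange of the cyano of compound 1 for the 1-hydroxy-1-methylethyl of compound 2, which moved the number by a 1.3-fold lower number from compound 1 to compound 2 (0.11 log units; within the scatter) and so showed no effect beyond the scatter. Since one substitution at this saturated chain carbon bound to a carbonyl carbon left the read-out essentially unchanged, a second substitution there is expected to do the same, and the step of a 1.1-fold higher number from compound 2 to compound 3 (0.03 log units; within the scatter) is expected to stay within the scatter. The estimated value for compound 3 in this assay is therefore 150 nM. The expected range for compound 3 runs from 70 nM to 330 nM.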

Compound 3, half-maximal inhibitory concentration: 100 nM
Estimate against measurement, compound 3: 1.5-fold (0.18 log units) above; measured number inside the range.
By their numbers in this assay, from the lowest: compounds 3, 2 and 1 (each within the scatter of the next).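

In this assay, the saturated chain carbon bound to a carbonyl carbon has now taken a third group, methylsulfonyl, with no step beyond the scatter: the exchange for 1-hydroxy-1-methylethyl gives a 1.4-fold lower number from compound 2 to compound 3 (0.15 log units; within the scatter) and the exchange for cyano gives a 1.8-fold lower number from compound 1 to compound 3 (0.26 log units; within the scatter) as its result. The first of these steps adds something the earlier pair could not show, as the leaving group has 1 hydrogen-bond donor and 1 hydrogen-bond acceptor, while the entering group has 0 hydrogen-bond donors and 2 hydrogen-bond acceptors, and the read-out still cannot tell the two compounds apart. Within these three compounds, then, the read-out does not separate the groups at this place, and no information is available on why that is so.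

The compounds shown leave open whether this insensitivity extends to an amine, a carboxylic acid or a longer chain at the same place, any of which could yet produce a step beyond the scatter. They also leave open whether the same holds with a different remainder of the molecule, as all three compounds share everything outside this one group.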